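Chloro Added to the Benzyl Ring of Compound 2

A few compounds are considered here, and "the series" means these few. Any claim that something is new, unique, unknown or untested is made for them only; others in the source may bear on it.

Measured so far:
compound 1, `O=C(CCCC1CCN(C(=O)c2ccccc2)CC1)c1ncco1`, 77 nM
compound 2, `O=C(CCCC1CCN(Cc2ccccc2)CC1)c1ncco1`, 315 nM

Both were tested in an assay on isolated protein for inhibition of Fatty-acid amide hydrolase 1 (Homo sapiens); on this read-out lower numbers stand for stronger inhibition and higher numbers for weaker inhibition. Compound 2 stands highest of the two numbers, its nearest neighbour being compound 1. Within the data shown here, the only measured step, a 4.1-fold higher number from compound 1 to compound 2 (0.61 log units; beyond the scatter), comes from a different change and gives no guidance on substituents of the phenyl ring.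

Compound 3, `O=C(CCCC1CCN(Cc2ccccc2Cl)CC1)c1ncco1`, differs from compound 2 by chloro in place of hydrogen on an aromatic carbon. Among the measured compounds shown here, no measured step bears on such a change, so no step beyond the scatter is expected. Compound 3 is therefore estimated at 300 nM, between 100 nM and 900 nM, an expected step of a 1.1-fold lower number from compound 2 to compound 3 (0.02 log units; within the scatter).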

Compound 3, half-maximal inhibitory concentration: 260 nM
For compound 3 the middle estimate is 1.2-fold (0.06 log units) above the measured one, within the range that was stated.
By their numbers in this assay, from the lowest: compound 1; then compounds 3 and 2 (each within the scatter of the next).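

Chloro on this aromatic carbon, ortho to a large group, leaves the number in this assay essentially unchanged (a 1.2-fold lower number from compound 2 to compound 3 (0.08 log units; within the scatter)), so this position accepts a chlorine atom without a measurable gain or loss. The 2-chlorobenzyl group also does not make up the difference from the benzoyl group of compound 1 (a 3.4-fold higher number from compound 1 to compound 3 (0.53 log units; beyond the scatter)). Nothing available explains either result.

Still open, as far as these compounds go, is whether a methoxy group or a carboxylic acid at this position would shift the number beyond the scatter. Whether chloro would behave the same way on the benzoyl ring of compound 1 is also unknown.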